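The source may report more compounds than this note shows. Statements on the series, on what has been measured and on what is new or still open speak of the compounds shown alone.

In an assay on cells with melanin-concentrating hormone receptor 1 (Homo sapiens) as the target, read by radioligand binding (on this read-out higher numbers stand for weaker inhibition and lower numbers for stronger inhibition), compound 3 `CSCCOc1cccc2ccc(N)nc12` reports only a limit, > 2000 nM, which is the limit of > 2000 nM in this assay, at which 1 of the 3 values shown sits. The step to compound 4 `Nc1ccc2cccc(OCC3CCC3)c2n1` is cyclobutyl in place of (methylsulfanyl)methyl on a saturated chain carbon bound to an oxygen on an aromatic ring. For the measured compounds named here, two measured steps bear on it. Compound 1 `Nc1ccc2cccc(OCC3CCCC3)c2n1` gives 53 nM in this assay, and an at least 37-fold higher number from compound 1 to compound 3 (1.57 log units; beyond the scatter). Compound 2 `COC(C)(C)CCOc1cccc2ccc(N)nc12` gives 132 nM in this assay, and an at least 15-fold higher number from compound 2 to compound 3 (1.18 log units; beyond the scatter). Both steps show that replacing the (methylsulfanyl)methyl group with a larger carbon-only group is followed by a much lower number, and cyclobutyl is closer to the cyclopentyl of compound 1 than to the 2-methoxy-2-methylpropyl of compound 2. Compound 4 is therefore expected to show a large step downward, an at least 25-fold lower number from compound 3 to compound 4 (1.39 log units; beyond the scatter), in this assay. Compound 4 is estimated at 80 nM, with a range from 30 nM to 300 nM.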

Compound 4, half-maximal inhibitory concentration: 432 nM
The estimate for compound 4 lay 5.4-fold (0.73 log units) below the measured number; the whole stated range lies below it.
By their numbers in this assay, from the lowest: compound 1; then compound 2; then compound 4. At a limit, above all of these: compound 3.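

In this assay, the ring size on this chain carbon proves to matter, as cyclobutyl in place of cyclopentyl gives an 8.2-fold higher number from compound 1 to compound 4 (0.91 log units; beyond the scatter). The open-chain 2-methoxy-2-methylpropyl also gives a lower number than cyclobutyl, with a 3.3-fold higher number from compound 2 to compound 4 (0.51 log units; beyond the scatter), so a carbon-only ring is not enough on its own. Cyclobutyl in place of (methylsulfanyl)methyl still gives an at least 4.6-fold lower number from compound 3 to compound 4 (0.66 log units; beyond the scatter), a size that rests on a limit and not a number: the limit of > 2000 nM in this assay, at which 1 of the 4 values shown sits.

On these data alone, whether a cyclohexyl ring, a longer chain or an amine at this place would match cyclopentyl remains open.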